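Lengthening the amine chain on the shared core

A few compounds are considered here, and "the series" means these few. Any claim that something is new, unique, unknown or untested is made for them only; others in the source may bear on it.

Compound 1, `CS(=O)(=O)Oc1c(C(=O)NCc2ccc(F)cc2)nc(Br)c2cccnc12`, gives > 20000 nM in a functional assay on HCT-116 cells (Homo sapiens) for cytotoxicity, read by MTT assay, with a stated time of 72 h (on this read-out lower numbers stand for stronger inhibition and higher numbers for weaker inhibition), which is a limit of the assay.
Compound 2, `C[C@@H](Nc1c(C(=O)NCc2ccc(F)cc2)nc(Br)c2cccnc12)c1ccccc1`, gives > 20000 nM in this assay, again a limit.
Compound 3, `NCCNc1c(C(=O)NCc2ccc(F)cc2)nc(Br)c2cccnc12`, gives > 20000 nM in this assay, also a limit.

All three measured compounds sit at the same limit, (the limit of > 20000 nM in this assay, at which 3 of the 3 values shown sit), so compound 3 stands level with the others and no ordering among them can be read. The steps a step that the two limits leave unreadable from compound 1 to compound 2, a step that the two limits leave unreadable from compound 1 to compound 3 and a step that the two limits leave unreadable from compound 2 to compound 3 carry no readable size, since each compares two limits.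

Compound 4, `CNCCCNc1c(C(=O)NCc2ccc(F)cc2)nc(Br)c2cccnc12`, is not yet measured. It differs from compound 3 by (methylamino)methyl in place of amino on a saturated chain carbon, two bonds along the chain from a nitrogen on an aromatic ring. For the measured compounds named here, no measured step touches this part of the chain, and the steps among the three measured compounds give no size in either direction. Going by the values given here, the only guide is that every variation made so far among compounds 1 to 3 left the value at the limit, (the limit of > 20000 nM in this assay, at which 3 of the 3 values shown sit).

Compound 4 is therefore expected to give 25000 nM, within 8000 nM to 80000 nM, most likely again as a limit. The expected step is a step that the limit leaves unreadable from compound 3 to compound 4, meaning no change beyond the scatter is anticipated.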

Compound 4, half-maximal inhibitory concentration: 9000 nM
For compound 4 the middle estimate is 2.8-fold (0.44 log units) above the measured one; the measured number falls inside the stated range.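

Going from 2-aminoethyl to 3-(methylamino)propyl on the nitrogen gives an at least 2.2-fold lower number from compound 3 to compound 4 (0.34 log units; beyond the scatter) in this assay, which shows that the far end of this chain can shift the read-out in the cells. Against the other two groups at this position, 3-(methylamino)propyl in place of 1-phenylethyl on the nitrogen gives an at least 2.2-fold lower number from compound 2 to compound 4 (0.34 log units; beyond the scatter), and (3-(methylamino)propyl)amino in place of (methylsulfonyl)oxy on the aromatic carbon gives an at least 2.2-fold lower number from compound 1 to compound 4 (0.34 log units; beyond the scatter). The steps among compound 1, compound 2 and compound 3 cannot be read, and the three new sizes are only minimum sizes, as each starts from a limit: the limit of > 20000 nM in this assay, at which 3 of the 4 values shown sit.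

This change lengthens the chain and adds a methyl on its end nitrogen in one move, so the compounds shown do not tell which of the two matters, and a 3-aminopropyl chain with a plain primary amine at its end would separate them. From the compounds shown here alone, how far the trend runs also stays open, and a longer chain such as 4-(methylamino)butyl or a 3-(dimethylamino)propyl group would test it in both length and substitution.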